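Cytotoxicity notes on the indolyl-thiazole series

The source may report more compounds than this note shows. Statements on the series, on what has been measured and on what is new or still open speak of the compounds shown alone.

Compound 1 `COc1ccc2[nH]cc(-c3cnc(N(C)[C@@H]4C[C@H]5O[C@@](C)([C@@H]4OC)n4c6ccccc6c6c7c(c8c9ccccc9n5c8c64)C(=O)NC7)s3)c2c1` — in an ADME assay on PBMC cells (Homo sapiens) for cytotoxicity, read by CellTiter-Glo, with a stated time of 72 h (on this read-out lower numbers stand for stronger inhibition and higher numbers for weaker inhibition), compound 1 gives > 10000 nM, a limit of the assay.
Compound 2 `CO[C@@H]1[C@H](N(C)c2ncc(-c3c[nH]c4ccc(Cl)cc34)s2)C[C@H]2O[C@]1(C)n1c3ccccc3c3c4c(c5c6cc(Cl)ccc6n2c5c31)C(=O)NC4` — in this assay compound 2 gives > 10000 nM, a limit of the assay.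
Compound 3 `CO[C@@H]1[C@H](N(C)c2ncc(-c3c[nH]c4ccc(Br)cc34)s2)C[C@H]2O[C@]1(C)n1c3ccccc3c3c4c(c5c6cc(Cl)ccc6n2c5c31)C(=O)NC4` — in this assay compound 3 gives > 10000 nM, a limit of the assay.

Compound 3 stands at the limit of this assay, as do the other two measured compounds; no readable number separates any of them, and this is the whole of the evidence: the limit of > 10000 nM in this assay, at which 3 of the 3 values shown sit.

Compound 4 `COc1ccc2[nH]cc(-c3cnc(N(C)[C@@H]4C[C@H]5O[C@@](C)([C@@H]4OC)n4c6ccccc6c6c7c(c8c9cc(Cl)ccc9n5c8c64)C(=O)NC7)s3)c2c1` is not yet measured. It differs from compound 3 in one place, (methoxy in place of bromo on an aromatic carbon). Within the data shown here, the only measured step that touches this part of the structure is the one from compound 2 to compound 3, a step that the two limits leave unreadable from compound 2 to compound 3, which is therefore uninformative about size or direction. The change toward compound 4 reintroduces the methoxy group of compound 1, whose value is likewise only a limit.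

Accordingly, compound 4 is expected to sit at the limit as well, giving an expected step that the limit leaves unreadable from compound 3 to compound 4 of no readable size. The estimated value for compound 4 in this assay is 20000 nM, with an expected range from 8000 nM to 60000 nM.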

Compound 4, half-maximal inhibitory concentration: > 10000 nM
Compound 4 was reported as a limit; the forecaster's own chance of this, stated with the estimate: 85%; the middle value lies beyond the limit too.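

Compound 4 joins compound 1, compound 2 and compound 3 at a limit in this assay, so no step among these compounds can be read: the limit of > 10000 nM in this assay, at which 4 of the 4 values shown sit. The compounds shown leave open whether the chloro, bromo or methoxy exchanges change cytotoxicity at all, and at what concentration any of these compounds would reach half-maximal inhibition.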